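This account rests on a few compounds, and the source may have more. Where it says the series, first, only, none or still open, it means among the compounds named here.

Working notes on the series. Among the compounds with values here, compound 1 `c1cncc(N2CC[C@@H]3CN[C@@H]3C2)c1` gives 330 nM in a functional assay on HEK293 cells for agonist activity at Neuronal acetylcholine receptor; alpha4/beta2 (Homo sapiens), read by FLIPR (on this read-out lower numbers stand for an effect already at smaller amounts and higher numbers for an effect only at larger amounts of compound), the highest of the three numbers measured so far. Compound 2 `Clc1ccc(N2CC[C@H]3CN[C@H]3C2)cn1` gives 13 nM and compound 3 `Clc1ccc(N2CC[C@@H]3CN[C@@H]3C2)cn1` gives 24 nM; the step of a 1.8-fold higher number from compound 2 to compound 3 (0.27 log units; within the scatter) stays within the scatter, in keeping with the fact that compounds 2 and 3 differ only in the configuration as drawn. Within the data shown here, the one substituent step measured, a 14-fold lower number from compound 1 to compound 3 (1.14 log units; beyond the scatter), is large.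

Compound 4 `Brc1cncc(N2CC[C@@H]3CN[C@@H]3C2)c1` is the next to be measured. Against compound 1 the change is bromo in place of hydrogen on an aromatic carbon. The bromo enters two atoms from the ring nitrogen, meta to a group of 8 heavy atoms. Among the measured compounds shown here, the only measured step that bears on it is the halogen entry from compound 1 to compound 3, a 14-fold lower number from compound 1 to compound 3 (1.14 log units; beyond the scatter), which points toward a lower number in this assay after a halogen enters the aromatic ring. For the measured compounds named here, since no bromo step and no step at this place of the ring have been measured, the expected gain is taken smaller than that one. Compound 4 is therefore estimated at 70 nM, with a range from 15 nM to 300 nM, an expected step of a 4.7-fold lower number from compound 1 to compound 4 (0.67 log units; beyond the scatter).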

Compound 4, half-maximal effective concentration: 1000 nM
Compound 4: middle estimate off by 14-fold (1.15 log units), on the low side; measured number outside the range, above it.
By their numbers in this assay, from the lowest: compounds 2 and 3 (each within the scatter of the next); then compound 1; then compound 4.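

In this assay bromo in place of hydrogen, two atoms from the ring nitrogen, gives a 3.0-fold higher number from compound 1 to compound 4 (0.48 log units; beyond the scatter) and so moves the number up, not down. The chloro step of a 14-fold lower number from compound 1 to compound 3 (1.14 log units; beyond the scatter) runs the other way, which means that the two halogen entries on the core of compound 1 have opposite directions and that the drop seen with compound 3 does not extend to this halogen at this place. Nothing on hand accounts for this reversal.

Open, as far as these compounds go, is whether the rise belongs to bromo itself or to this place on the ring: chloro, methyl or an amine here, or bromo at the place that chloro holds in compound 3, would separate the two. Also open, from the compounds shown here alone, is whether the mirror image of compound 4 stays close to compound 4.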